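The source may hold more compounds than are shown below. What is called first, only, known or untested is meant among the compounds shown, and "the series" means these compounds.

Measured compounds:
- compound 1 `COc1cc(Cl)cc(-c2nn(-c3cccc(NC(=O)c4ccc(Cl)c(Cl)c4)c3)cc2-c2ccncc2)c1` gives 75.3% in a functional assay on NCI-H23 cells (Homo sapiens) for inhibition, read by sulforhodamine B assay, with a stated time of 48 h, tested at 10 uM; a higher number here means a weaker effect of the compound at the concentration tested, a lower number a stronger effect
- compound 2 `COc1cc(Cl)cc(-c2nn(-c3cccc(NC(=O)Nc4ccc(Cl)c(Cl)c4)c3)cc2-c2ccncc2)c1` gives 5.72% in this assay
- compound 3 `COc1cc(Cl)cc(-c2nn(-c3cccc(NC(=O)c4cccc(C(F)(F)F)c4)c3)cc2-c2ccncc2)c1` gives 55.7% in this assay

Among these three numbers compound 3 stands second highest: compound 1 lies above it by a number 19.6 percentage points lower from compound 1 to compound 3 (beyond the scatter) read the other way, and compound 2 lies far below it, as a number 50 percentage points higher from compound 2 to compound 3 (beyond the scatter) shows. The largest movement in the set is a number 69.6 percentage points lower from compound 1 to compound 2 (beyond the scatter), where the aryl on the carbonyl carbon is replaced by an arylamino group.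

The unmeasured compound 4 `COc1cc(Cl)cc(-c2nn(-c3cccc(NC(=O)c4cc(C(F)(F)F)cc(C(F)(F)F)c4)c3)cc2-c2ccncc2)c1` differs from compound 3 by trifluoromethyl in place of hydrogen on an aromatic carbon. Within the data shown here, only one measured step touches the aryl on the carbonyl carbon while keeping it an aryl: a number 19.6 percentage points lower from compound 1 to compound 3 (beyond the scatter), a modest step, where a disubstituted ring gave way to a monosubstituted one. Compound 4 returns to a disubstituted ring, though with a different pair of groups, so the prose writer expects a small rise in this assay, or none beyond the scatter, rather than the large drop seen for compound 2. Compound 4 is therefore estimated at 62%, within 38% to 86%, an expected step of a number 6.3 percentage points higher from compound 3 to compound 4 (within the scatter).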

Compound 4, a percentage reported as activity, at one concentration (the size of the read-out at that concentration, not a potency): 72.1%
Compound 4: the middle estimate sits 10.1 percentage points below what was measured; the measured number falls inside the stated range.
By their numbers in this assay, from the lowest: compound 2; then compound 3; then compounds 4 and 1 (each within the scatter of the next).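

With the amide link and the rest of compound 3 held fixed, one added trifluoromethyl on an aromatic carbon, meta to the existing trifluoromethyl group, gives a number 16.4 percentage points higher from compound 3 to compound 4 (beyond the scatter) in this assay, which means a weaker effect at the concentration tested. The earlier steps shown here exchanged whole groups on the carbonyl carbon, whereas this one changes a single ring position and shows that the read-out responds to what stands there, even with the link unchanged. The step is modest, and as a single change it sets no trend for substituents on this ring. No measurement here accounts for the change.

Going by these compounds, it remains open whether a nitrile or an amine on this same aromatic carbon would move the number in the same direction as trifluoromethyl, or whether the direction belongs to this one group alone. On these data alone, it is also open whether the pair of trifluoromethyl groups would carry the same upward step on the urea link of compound 2, which gives 5.72% in this assay.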